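Solubility of a tert-butyl-bearing analogue of compound 1

The source may report more compounds than this note shows. Statements on the series, on what has been measured and on what is new or still open speak of the compounds shown alone.

Measured compounds:
- Compound 1, `COc1cccc(CNCCCNc2ccnc3cc(Oc4ccccc4)ccc23)c1O`: 14500 nM
- Compound 2, `c1ccc(Oc2ccc3c(NCCCNCc4ccco4)ccnc3c2)cc1`: 14500 nM
- Compound 3, `COc1ccc(F)cc1CNCCCNc1ccnc2cc(Oc3ccccc3)ccc12`: 14500 nM

In a physicochemical assay for solubility, with a stated time of 18 h, at pH 7.4 (a higher number here means a more soluble compound, a lower number a less soluble compound), compound 1 gives 14500 nM and stands level with compounds 2 and 3. The step from compound 1 to compound 2 (no change at the digits printed from compound 1 to compound 2 (within the scatter)) and the step from compound 1 to compound 3 (no change at the digits printed from compound 1 to compound 3 (within the scatter)) both replace the group on a saturated chain carbon bound to an amine nitrogen, and neither moves this assay beyond its scatter; the same holds for no change at the digits printed from compound 2 to compound 3 (within the scatter).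

Compound 4, `COc1cccc(CNCCCNc2ccnc3cc(Oc4ccc(C(C)(C)C)cc4)ccc23)c1O`, differs from compound 1 elsewhere: tert-butyl in place of hydrogen on an aromatic carbon, on an aromatic carbon of a six-membered aromatic ring of carbon only, para to a large group. None of the three measured steps touches that ring, so they give no direct guide to the size or direction of this change. Compound 4 is therefore expected near compound 1, with a wide range, and the estimated step is a 1.6-fold lower number from compound 1 to compound 4 (0.21 log units; within the scatter). The estimate for compound 4 is 9000 nM, between 2500 nM and 20000 nM.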

Compound 4, solubility: 14500 nM
The estimate for compound 4 lay 1.6-fold (0.21 log units) below the measured number; measured number inside the range.
By their numbers in this assay, from the lowest: compounds 1, 2, 3 and 4 (each within the scatter of the next).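

In this assay, among the compounds shown here, the earlier compounds differ only in the group on a saturated chain carbon bound to an amine nitrogen, whereas this result is the first reading of a change elsewhere, from phenoxy to 4-(tert-butyl)phenoxy. Tert-butyl in place of hydrogen on this aromatic carbon, para to a large group, gives no change at the digits printed from compound 1 to compound 4 (within the scatter) and so shows that this addition of 4 carbon atoms, made to compound 1, leaves the read-out within its scatter. No measurement shown bears on why the number stays level.

As far as these compounds go, whether an amine or a carboxylic acid on this same carbon would also read level remains open. So does whether tert-butyl gives the same reading when furan-2-yl or 5-fluoro-2-methoxyphenyl replaces 2-hydroxy-3-methoxyphenyl.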